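Acylguanidine series: arylthio replacement for pentyl

The source may report more compounds than this note shows. Statements on the series, on what has been measured and on what is new or still open speak of the compounds shown alone.

Compound 2 `CCCCCc1cc(C)c(C(=O)N=C(N)N)cc1S(C)(=O)=O` gives 27 nM in a functional assay for inhibition of sodium/hydrogen exchanger (Oryctolagus cuniculus) (a lower number here means a stronger inhibitor, a higher number a weaker inhibitor), and stands at the lowest number of the three measured. Compound 3 `Cc1c(C(=O)N=C(N)N)cc(S(C)(=O)=O)c(C)c1C` gives 55 nM and compound 1 `Cc1c(C(=O)N=C(N)N)cc(S(C)(=O)=O)c(Cl)c1C` gives 58 nM; both sit beyond the scatter above compound 2. Among the measured compounds shown here, the only single-point step measured, a 1.1-fold lower number from compound 1 to compound 3 (0.02 log units; within the scatter), lies within the scatter and concerns the chloro-for-methyl exchange, not the position changed here.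

Compound 4 `Cc1cc(Sc2cccc(Cl)c2)c(S(C)(=O)=O)cc1C(=O)N=C(N)N` differs from compound 2 by (3-chlorophenyl)sulfanyl in place of pentyl on an aromatic carbon. For the measured compounds named here, no measured pair isolates this change; the entering group brings a second aromatic ring and a sulfur, for which no precedent exists among the three values.

The expectation therefore rests on compound 2 alone, because its 27 nM is the starting point, and on the absence of any measured step at this position. Compound 4 is expected to stay near compound 2, with a 1.4-fold lower number from compound 2 to compound 4 (0.13 log units; within the scatter) as the estimated step. For compound 4 the estimate is 20 nM, with a range from 6 nM to 70 nM.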

Compound 4, half-maximal inhibitory concentration: 37 nM
Estimate against measurement, compound 4: 1.9-fold (0.27 log units) below; measured number inside the range.
By their numbers in this assay, from the lowest: compounds 2, 4, 3 and 1 (each within the scatter of the next, the first and the last beyond it).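

In this assay, (3-chlorophenyl)sulfanyl in place of pentyl gives a 1.4-fold higher number from compound 2 to compound 4 (0.14 log units; within the scatter). Among the compounds shown here, this is the first step read at this position, ortho to a methylsulfonyl group and meta to a methyl group, and it shows that an open carbon chain and a sulfur-linked aromatic ring read alike here, within the two compounds compared. No measurement available bears on why these two different groups give numbers within the scatter of each other.

Open, from the compounds shown here alone, is whether the sulfur or the chlorine in the entering group matters at all, which an unsubstituted phenylsulfanyl or a phenoxy group at the same position would help to separate. Also open, going by these compounds, is whether this position keeps its numbers with an amine or a carboxylic acid there, or with a chain shorter than pentyl.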